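Clearance notes: trifluoromethyl in place of fluoro

The source may hold more compounds than are shown below. What is called first, only, known or untested is meant among the compounds shown, and "the series" means these compounds.

- Compound 1 `CC(=O)Nc1cccc(Cn2cc(-c3ccc4c(N)n[nH]c4c3)ccc2=O)c1`: 14 mL.min-1.g-1
- Compound 2 `Nc1n[nH]c2cc(-c3ccc(=O)n(Cc4cccc(F)c4)c3)ccc12`: < 10 mL.min-1.g-1 (a limit, not a number)

All values come from an ADME assay on microsomes (Mus musculus) for metabolic stability, read by LC-MS, using NADPH, with a stated time of 1 h, tested at 1 uM; a higher number here means faster removal of the compound, a lower number slower removal. Compound 2 stands at the limit of < 10 mL.min-1.g-1 in this assay, at which 1 of the 2 values shown sits, so only a limit is known for it.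

Compound 3 `Nc1n[nH]c2cc(-c3ccc(=O)n(Cc4cccc(C(F)(F)F)c4)c3)ccc12` carries trifluoromethyl in place of fluoro on an aromatic carbon. The change lies on a six-membered aromatic ring of carbon only, meta to a large group. Among the measured compounds shown here, one measured step bears on the same aromatic carbon: an at least 1.4-fold lower number from compound 1 to compound 2 (0.14 log units; that floor lies within the scatter). For the measured compounds named here, that step gives only a floor on its size, and no compound with trifluoromethyl has been measured yet. No step beyond the scatter is therefore expected in this assay, and no firm direction can be drawn from the data. The expected step is an at least 1.1-fold higher number from compound 2 to compound 3 (0.04 log units; that floor lies within the scatter). For compound 3 the estimated value is 11 mL.min-1.g-1, with an expected range from 6 mL.min-1.g-1 to 25 mL.min-1.g-1.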

Compound 3, intrinsic clearance in microsomes: < 10 mL.min-1.g-1
Compound 3: a limit, no number; the forecaster's own chance of this, stated with the estimate: 40%; at least 1.1-fold (0.04 log units) between middle value and limit.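

In this assay compound 3 gives a limit and not a number, so trifluoromethyl on this aromatic carbon joins fluoro as a group known only through a limit. Set against acetamido on the same carbon, the change gives an at least 1.4-fold lower number from compound 1 to compound 3 (0.14 log units; that floor lies within the scatter), which fixes no direction for this position. The step between fluoro and trifluoromethyl cannot be read, and the series now rests largely on one limit: the limit of < 10 mL.min-1.g-1 in this assay, at which 2 of the 3 values shown sit.

Left open is how far fluoro, trifluoromethyl and acetamido truly lie apart at this position, since only one of the three carries a number. An amine or a carboxylic acid on the same aromatic carbon could show whether any other group here gives a readable number in this assay.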